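Swapping the benzyl group: methoxy out, chlorine in

The source may report more compounds than this note shows. Statements on the series, on what has been measured and on what is new or still open speak of the compounds shown alone.

Measured so far:
compound 1 `COc1ccc(CNCCCNS(=O)(=O)c2cc(C(F)(F)F)cc(C(F)(F)F)c2)cc1OC` — 13000 nM
compound 2 `O=S(=O)(NCCCNCc1cccc2ccccc12)c1cc(C(F)(F)F)cc(C(F)(F)F)c1` — 2700 nM
compound 3 `COc1ccc(CNCCCNS(=O)(=O)c2cc(C(F)(F)F)cc(C(F)(F)F)c2)cc1` — 1300 nM

All three share one core and differ only in the aromatic ring carried on the saturated chain carbon bound to an amine nitrogen. In a functional assay on BXPC-3 cells (Homo sapiens) for inhibition, read by MTT assay, with a stated time of 72 h (a higher number here means a weaker inhibitor of growth, a lower number a stronger inhibitor of growth), compound 3 gives 1300 nM, the lowest number of the three; compound 2 stands nearest to it, compound 1 furthest. The step of a 10-fold lower number from compound 1 to compound 3 (1.00 log units; beyond the scatter) and the step of a 2.1-fold lower number from compound 2 to compound 3 (0.32 log units; beyond the scatter) both point toward compound 3, and a 4.8-fold lower number from compound 1 to compound 2 (0.68 log units; beyond the scatter) shows the other pairing.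

Compound 4 `O=S(=O)(NCCCNCc1cccc(Cl)c1)c1cc(C(F)(F)F)cc(C(F)(F)F)c1` has not been measured. Its change from compound 3 is 3-chlorophenyl in place of 4-methoxyphenyl on a saturated chain carbon bound to an amine nitrogen. Among the measured compounds shown here, no measured step removes a methoxy and adds a chlorine at once, so the earlier steps bear only loosely on it: they show that this ring position tolerates different aromatic groups with modest shifts in either direction. A step in this assay of about a 1.2-fold higher number from compound 3 to compound 4 (0.06 log units; within the scatter) is therefore expected, close to or within the scatter. Compound 4 is estimated at 1500 nM, with a range from 500 nM to 4500 nM.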

Compound 4, concentration for 50% growth inhibition: 3800 nM
Compound 4: the middle estimate sits 2.5-fold (0.40 log units) below what was measured; the measured number falls inside the stated range.
By their numbers in this assay, from the lowest: compound 3; then compounds 2 and 4 (each within the scatter of the next); then compound 1.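

In this assay, 3-chlorophenyl on the saturated chain carbon bound to an amine nitrogen does not match 4-methoxyphenyl (a 2.9-fold higher number from compound 3 to compound 4 (0.47 log units; beyond the scatter)). It cannot be told apart from naphthalen-1-yl (a 1.4-fold higher number from compound 2 to compound 4 (0.15 log units; within the scatter)), yet it still gives a stronger inhibitor of growth than 3,4-dimethoxyphenyl (a 3.4-fold lower number from compound 1 to compound 4 (0.53 log units; beyond the scatter)). Compound 3 and compound 1 both carry methoxy and sit at opposite ends of this small set, while the methoxy-free compound 4 falls between them, so the presence of methoxy alone does not set the order.

Nothing shown here explains this order. The compounds also leave open how 4-chlorophenyl or 3-methoxyphenyl would compare, and these two groups would help separate the choice of group from its place on the ring.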